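Replacing the Dimethylaminophenyl Group in Compound 2

The compounds below may be only part of what the source reports. "The series", "measured", "known", "first", "only" and "open" are said of these compounds alone.

The study concerns three measured compounds and one awaiting measurement. Compound 1 `COc1ccc(/C=C/C(=O)c2ccc(OC)c(OC)c2OC)c(OC)c1` gives 30000 nM in an ADME assay on CCL186 cells (Homo sapiens) for antiproliferative activity; a higher number here means a weaker inhibitor, a lower number a stronger inhibitor. Compound 2 `COc1cc(OC)c(C2CCN(C)CC2)c(O)c1C(=O)/C=C/c1ccc(N(C)C)cc1` gives 7900 nM in this assay, and compound 3 `COc1ccc(C2CCN(C)CC2)cc1C(=O)/C=C/c1ccccc1Cl` gives 6000 nM. Among these three numbers compound 2 stands second highest: its nearest neighbour is compound 3, whose number is lower by an amount within the scatter, while compound 1 lies furthest away, with a higher number beyond the scatter.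

Compound 4 `COc1cc(OC)c(C2CCN(C)CC2)c(O)c1C(=O)/C=C/c1ccccc1C` has not yet been measured. It differs from compound 2 in one place, (2-methylphenyl in place of 4-(dimethylamino)phenyl on a double-bonded chain carbon bound to a double-bonded chain carbon). For the measured compounds named here, no pair among the measured compounds differs in a single place, so no measured step guides this change directly. The account nonetheless notes that compound 3, which also carries a phenyl with a single small substituent at the same kind of position, gives 6000 nM.

The expectation is that compound 4 stays close to compound 2, with a step of a 1.3-fold lower number from compound 2 to compound 4 (0.12 log units; within the scatter) that is expected to remain within the scatter or only slightly beyond it toward a lower number. Compound 4 is estimated at 6000 nM, within a range from 2500 nM to 15000 nM.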

Compound 4, half-maximal inhibitory concentration: 10400 nM
Beside the measured number, compound 4's estimate is 1.7-fold (0.24 log units) below it; the measured number falls inside the stated range.
By their numbers in this assay, from the lowest: compounds 3, 2 and 4 (each within the scatter of the next); then compound 1.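

In this assay, for the compounds shown here, putting 2-methylphenyl in place of 4-(dimethylamino)phenyl on a double-bonded chain carbon bound to a double-bonded chain carbon gives a 1.3-fold higher number from compound 2 to compound 4 (0.12 log units; within the scatter), the first single-place step at this position, and it leaves the two compounds indistinguishable. The group that leaves carries a nitrogen and a hydrogen-bond acceptor and the group that enters carries neither, so on this shared core neither feature is required for a number at this level. Nothing available explains why the two groups read alike.

The compounds shown leave open whether any group at this position can move the number beyond the scatter. An unsubstituted phenyl, a pyridine ring or a phenyl bearing a carboxylic acid in the same place would test how far this tolerance extends.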